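Trimming a Benzyloxy Group to Methoxy

The source may hold more compounds than are shown below. What is called first, only, known or untested is meant among the compounds shown, and "the series" means these compounds.

Of the compounds shown here, three sharing one core have been tested in a functional assay on SF-295 cells (Homo sapiens) for cytotoxicity, read by MTT assay, with a stated time of 72 h (on this read-out higher numbers stand for weaker inhibition and lower numbers for stronger inhibition), so far, and only one of them gave a number. Within the data shown here, compound 2 (`C=CC(C)(C/C=C(\C)CCC=C(C)C)c1ccc(O)c(OCc2ccccc2)c1`) gives 18.2 ug/mL and so holds the only numerical value in the set. Compound 1 (`C=CC(C)(C/C=C(\C)CCC=C(C)C)c1ccc(OCc2ccccc2)c(OCc2ccccc2)c1`) is recorded as "not active" (no number reported) with no figure to compare. Compound 3 (`C=CC(C)(C/C=C(\C)CCC=C(C)C)c1ccc(OC(=O)c2ccccc2)c(OC(=O)c2ccccc2)c1`) is likewise recorded as "not active" (no number reported) in this series. Neither of these two carries a free hydroxy group on the aromatic ring, whereas compound 2 does, though three compounds cannot settle what that means.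

Compound 4 (`C=CC(C)(C/C=C(\C)CCC=C(C)C)c1ccc(O)c(OC)c1`) has not yet been measured. Its difference from compound 2 is hydrogen in place of phenyl on a saturated chain carbon bound to an oxygen on an aromatic ring and amounts to hydrogen in place of phenyl on a saturated chain carbon bound to an oxygen on an aromatic ring, which turns benzyloxy into methoxy. Among the measured compounds shown here, no measured pair shows this change, so the data give no direct guide to its size. Compound 4 keeps the free hydroxy group, so the expectation rests on compound 2 at 18.2 ug/mL and not on the two compounds without a number. The expected step of a 1.5-fold lower number from compound 2 to compound 4 (0.18 log units; within the scatter) leans slightly towards stronger inhibition but stays within the usual scatter. In this assay compound 4 is expected to read 12 ug/mL within an estimated range of 5 ug/mL to 30 ug/mL on this reasoning.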

Compound 4, half-maximal inhibitory concentration: 20.7 ug/mL
Compound 4: middle estimate off by 1.7-fold (0.24 log units), on the low side; the measured number falls inside the stated range.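

Hydrogen in place of phenyl on a saturated chain carbon bound to an oxygen on an aromatic ring, which turns benzyloxy into methoxy, gives a 1.1-fold higher number from compound 2 to compound 4 (0.06 log units; within the scatter) in this assay and is the first measured step in this series. At this place, therefore, the read-out does not distinguish benzyloxy from methoxy, and compound 2 does not need the phenyl to give a number in this assay. Nothing shown here explains why removing the phenyl leaves the two compounds indistinguishable.

The compounds shown bracket only two groups at this place, so it remains open whether an ethoxy group, a longer chain ending in an amine or a carboxylic acid, or a hydroxy group in place of the benzyloxy would also leave the number within the usual scatter. On these data alone, it also remains open whether the pattern holds with the free hydroxy group replaced by a methoxy or acetoxy group on the methoxy-bearing compound 4, and whether the shared core's long unsaturated chain contributes to the read-out.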